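Fluoro for Methoxy on a Nitrobenzamide Series

The source may hold more compounds than are shown below. What is called first, only, known or untested is meant among the compounds shown, and "the series" means these compounds.

Compound 1, `COc1ccc(-c2nc3ccccc3o2)cc1NC(=O)c1cc([N+](=O)[O-])ccc1Cl`, in an ADME assay on BJ cells (Homo sapiens) for cytotoxicity, with a stated time of 72 h (a higher number here means that more compound is needed for the effect, a lower number that less compound is needed), gives only the assay limit of > 25000 nM.
Compound 2, `COc1ccc(-c2nc3ccccc3s2)cc1NC(=O)c1cc([N+](=O)[O-])ccc1Cl`, in this assay likewise gives only the limit > 25000 nM.
Compound 3, `COc1ccc(-c2nc3ccccc3s2)cc1NC(=O)c1cc([N+](=O)[O-])c(N2CCN(C)CC2)cc1Cl`, in this assay also gives only the limit > 25000 nM.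

Compound 2 therefore stands at a limit in this assay, as do the two further values shown. The steps a step that the two limits leave unreadable from compound 1 to compound 2 and a step that the two limits leave unreadable from compound 2 to compound 3 cannot be read because the limit of > 25000 nM in this assay, at which 3 of the 3 values shown sit, is where every value sits. Compound 4, `O=C(Nc1cc(-c2nc3ccccc3s2)ccc1F)c1cc([N+](=O)[O-])ccc1Cl`, differs from compound 2 by fluoro in place of methoxy on an aromatic carbon. Among the compounds with values here, no measured step bears on this change, so no step beyond the scatter is expected in this assay. Compound 4 is expected to give about 30000 nM, within 15000 nM to 60000 nM. The expected step is a step that the limit leaves unreadable from compound 2 to compound 4.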

Compound 4, half-maximal effective concentration: > 25000 nM
Compound 4 ended at the assay's limit; the forecaster's own chance of this, stated with the estimate: 80%; the middle value is on the limit's open side.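

No new step can be read between compound 2 and compound 4, because both values are limits: the limit of > 25000 nM in this assay, at which 4 of the 4 values shown sit.

The compounds shown leave open how fluoro and methoxy compare in this assay, as no compound here gives a value that is not a limit.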